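This account rests on a few compounds, and the source may have more. Where it says the series, first, only, none or still open, it means among the compounds named here.

Measured compounds:
Compound 1 `C=Cc1ccc(S(=O)(=O)Nc2ccc3oc(-c4ccccc4)nc3c2)cc1`: in an assay on cells for inhibition of HSP60/HSP10 (Homo sapiens), with a stated time of 60 min (on this read-out lower numbers stand for stronger inhibition and higher numbers for weaker inhibition), compound 1 gives > 100000 nM, which is a limit of the assay.
Compound 2 `COc1ccc(S(=O)(=O)Nc2ccc3oc(-c4ccccc4)nc3c2)cc1`: in this assay compound 2 gives > 100000 nM, also a limit.
Compound 3 `O=S(=O)(Nc1ccc2oc(-c3ccccc3)nc2c1)c1ccc(O)cc1`: in this assay compound 3 gives 88000 nM.

Compound 3 thus stands as the only one of the three with a number. Two of the three results sit at the limit of > 100000 nM in this assay, at which 2 of the 3 values shown sit.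

Compound 4 `O=S(=O)(Nc1ccc2oc(-c3ccccc3)nc2c1)c1ccc(C(F)(F)F)cc1` is not yet measured. It differs from compound 3 by trifluoromethyl in place of hydroxy on an aromatic carbon. For the measured compounds named here, two measured steps touch that same position: an at least 1.1-fold lower number from compound 1 to compound 3 (0.05 log units; that floor lies within the scatter) and an at least 1.1-fold lower number from compound 2 to compound 3 (0.05 log units; that floor lies within the scatter). Going by the values given here, both are floors lying within the scatter, so no measured step shows that changing this group moves the number much. The expected step is a 1.7-fold higher number from compound 3 to compound 4 (0.23 log units; within the scatter), most likely no change beyond the scatter and a fair chance of landing back at the limit. Compound 4 is therefore estimated at 150000 nM, within 50000 nM to 500000 nM.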

Compound 4, half-maximal inhibitory concentration: > 100000 nM
Compound 4 was reported as a limit; the forecaster's own chance of this, stated with the estimate: 65%; the middle value lies beyond the limit too.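

In this assay, trifluoromethyl in place of hydroxy gives an at least 1.1-fold higher number from compound 3 to compound 4 (0.05 log units; that floor lies within the scatter), so this change shows no shift beyond the scatter. The steps to compound 4 from compound 1 and from compound 2 cannot be read, as each joins two limits. Vinyl, methoxy and trifluoromethyl on this aromatic carbon now share one result: the limit of > 100000 nM in this assay, at which 3 of the 4 values shown sit.

On these data alone, whether an amine or a carboxylic acid on this carbon would give a clearly lower number stays open. So does whether changes elsewhere on the shared core would move the number.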